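This account rests on a few compounds, and the source may have more. Where it says the series, first, only, none or still open, it means among the compounds named here.

In an ADME assay on BJ cells (Homo sapiens) for cytotoxicity, read by CellTiter-Glo and resazurin assay, with a stated time of 72 h (a lower number here means that less compound is needed, a higher number that more compound is needed for the effect), the study holds two measured compounds. Compound 1, `CCOc1cccc(-c2ccc(C(=O)N(Cc3cccc(OCCCCCC(=O)O)c3)C(C)C)cc2)c1`, reaches only the limit of the assay and shows no number, > 20800 nM, as recorded in the limit of > 20800 nM in this assay, at which 1 of the 2 values shown sits. Compound 2, `CCOC(=O)CCCCCOc1cccc(CN(C(=O)c2ccc(-c3ccoc3)cc2)C(C)C)c1`, likewise stops at a limit, > 26000 nM, the line the limit of > 26000 nM in this assay, at which 1 of the 2 values shown sits, marking where that value sits. Compound 2 therefore stands at the edge of what this assay can report, with no number of its own; the other measured value is a limit as well.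

Compound 3, `CCOC(=O)CCCCCOc1cccc(CN(C(=O)c2ccc(-c3cccc(OCC)c3)cc2)C(C)C)c1`, has not yet been measured. It differs from compound 2 in one place: 3-ethoxyphenyl in place of furan-3-yl on an aromatic carbon. Among the measured compounds shown here, no measured step is recorded, so no size is known. Since compound 2 and compound 1 both return only limits, the step that the limit leaves unreadable from compound 2 to compound 3 is expected to be none beyond the scatter, most likely ending again at a limit. Compound 3 is estimated at 30000 nM, within 10000 nM to 90000 nM.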

Compound 3, half-maximal effective concentration: > 22300 nM
Compound 3: no number, only a limit (the forecaster's own chance of this, stated with the estimate: 80%); the middle value lies beyond the limit too.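

Compound 3 stops at a limit in this assay, as do compound 1 and compound 2, so neither step leading to compound 3 can be read. The compounds shown leave open what concentration any of the three needs for the effect, and whether either change shifts it.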